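The source may report more compounds than this note shows. Statements on the series, on what has been measured and on what is new or still open speak of the compounds shown alone.

Compound 1 `COc1ccc(N2C(=O)COc3ccc(-c4cnc5ccccc5c4)cc32)cc1` and compound 3 `COc1cccc(N2C(=O)COc3ccc(-c4cnc5ccccc5c4)cc32)c1` share a core and differ only in the aryl group on the ring amide nitrogen. In a functional assay on HepG2 cells (Homo sapiens) for antiproliferative activity, read by MTT assay, with a stated time of 72 h (a lower number here means a stronger inhibitor, a higher number a weaker inhibitor), compound 3 gives 2080 nM. Compound 1 reaches only the limit > 40000 nM in this assay. Among the measured compounds shown here, the step of an at least 19-fold lower number from compound 1 to compound 3 (1.28 log units; beyond the scatter) is the one measured change here. Compound 2 `COc1cccc(N2C(=O)COc3ccc(-c4cnc(Cl)c(NS(=O)(=O)c5ccc(F)cc5)c4)cc32)c1` carries the same 3-methoxyphenyl on that nitrogen but a different substituted pyridine. Compound 2 in this assay also sits at the limit > 40000 nM; it shares that position with another member of the set (the limit of > 40000 nM in this assay, at which 2 of the 3 values shown sit). Compound 4 `O=C1COc2ccc(-c3cnc(Cl)c(NS(=O)(=O)c4ccc(F)cc4)c3)cc2N1` differs from compound 2 by hydrogen in place of 3-methoxyphenyl on an amide-type nitrogen in a ring. For the measured compounds named here, no measured step removes the aryl group altogether, so no direction for a number no higher from compound 2 to compound 4 (the limit leaves the size open) is expected from the data. For compound 4 an estimate of 40000 nM (range 5000 nM to 100000 nM) is made, most likely again a limit.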

Compound 4, half-maximal inhibitory concentration: > 40000 nM
Compound 4 gave a limit, no number; the forecaster's own chance of this, stated with the estimate: 65%; the middle value sits exactly at the limit.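

Compound 2 and compound 4 both sit at a limit in this assay, so no step can be read between them. The compounds shown leave open whether 3-methoxyphenyl on the amide-type nitrogen in a ring affects activity when the substituted pyridine of compound 2 is present.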